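The source may report more compounds than this note shows. Statements on the series, on what has been measured and on what is new or still open speak of the compounds shown alone.

Measured so far:
compound 1 `Cc1nc(N2CCC(N3CCCC3=O)CC2)nc2ccc(NC(=O)/C=C/c3ccc(Cl)cc3)cc12` gives 74 nM in an assay on CHO-K1 cells for displacement of a labelled ligand from melanin-concentrating hormone receptor 1 (Homo sapiens), read by scintillation proximity assay, with a stated time of 2 h; a lower number here means a stronger inhibitor, a higher number a weaker inhibitor.
compound 2 `C/C(=C\C(=O)Nc1ccc2nc(N3CCC(O)(C4CC4)CC3)nc(C)c2c1)c1ccc(Cl)cc1` gives 532 nM.
compound 3 `Cc1nc(N2CCC(O)(C3CC3)CC2)nc2ccc(NC(=O)/C=C/c3ccc(Cl)cc3Cl)cc12` gives 620 nM.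

Compound 1 stands lowest of these three numbers, and its gap to each of the other two is beyond the scatter. Compound 4 `Cc1nc(N2CCC(N3CCCC3=O)CC2)nc2ccc(NC(=O)/C=C/c3ccc(OC(F)(F)F)cc3)cc12` differs from compound 1 in one place: trifluoromethoxy in place of chloro on an aromatic carbon. The only step measured between two of these compounds, a 1.2-fold higher number from compound 2 to compound 3 (0.07 log units; within the scatter), concerns a different group on the carbonyl side and does not touch the chloro group, so no measured step bears directly on this change. Without such a guide, the expected step is a 1.6-fold higher number from compound 1 to compound 4 (0.21 log units; within the scatter), which lies close to the scatter. Compound 4 is therefore estimated at 120 nM in this assay, with a range from 35 nM to 400 nM.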

Compound 4, half-maximal inhibitory concentration: 11 nM
Estimate against measurement, compound 4: 11-fold (1.04 log units) above; measured number outside the range, below it.
By their numbers in this assay, from the lowest: compound 4; then compound 1; then compounds 2 and 3 (each within the scatter of the next).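

In this assay, this position on the aromatic ring proves sensitive to what it carries: 4-(trifluoromethoxy)phenyl in place of 4-chlorophenyl gives a 6.7-fold lower number from compound 1 to compound 4 (0.83 log units; beyond the scatter). A group of five heavy atoms is thus accepted here in place of a single chlorine, with a lower number. No measurement shown explains the size of this step. Methoxy or trifluoromethyl at this place could separate the contribution of the oxygen from that of the fluorines. On these data alone, whether the same exchange would lower the number for compound 2 also remains open.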